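This account rests on a few compounds, and the source may have more. Where it says the series, first, only, none or still open, it means among the compounds named here.

Measured compounds:
compound 1, `C=CCNC(=O)/C(C)=C(/C)c1ccccc1`, 550 mg/kg
compound 2, `C=CCNC(=O)/C(C)=C(\C)c1ccc(OC)cc1`, 200 mg/kg
compound 3, `C=CCNC(=O)/C(C)=C(\C)c1ccc(Cl)cc1`, 70 mg/kg

In a toxicity assay on the whole organism (strain Icem-CET (SPF Caw)) for cytotoxicity, with Mus musculus as the target (on this read-out lower numbers stand for an effect already at smaller amounts and higher numbers for an effect only at larger amounts of compound), compound 3 gives 70 mg/kg, the lowest of the three numbers; its nearest neighbour is compound 2 with 200 mg/kg, and compound 1 with 550 mg/kg lies furthest away. Compound 4, `C=CCNC(=O)/C(C)=C(\C)c1ccccc1`, has not yet been measured. It differs from compound 3 in one place: hydrogen in place of chloro on an aromatic carbon. Among the measured compounds shown here, the only measured step that touches this position is a 2.9-fold lower number from compound 2 to compound 3 (0.46 log units; beyond the scatter), where a chloro was exchanged for a methoxy rather than removed; compound 1 also carries a hydrogen at this position but differs elsewhere in the shared core, so its value only hints that an unsubstituted ring goes with a higher number. Removing the chloro is therefore expected to raise the number, likely a 3.6-fold higher number from compound 3 to compound 4 (0.55 log units; beyond the scatter), in this assay. Compound 4 is estimated at 250 mg/kg, with a range from 100 mg/kg to 600 mg/kg.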

Compound 4, dose for half-maximal effect: 130 mg/kg
Compound 4: middle estimate off by 1.9-fold (0.28 log units), on the high side, and the stated range covers the measured number.
By their numbers in this assay, from the lowest: compounds 3, 4 and 2 (each within the scatter of the next, the first and the last beyond it); then compound 1.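

In this assay, among the compounds shown here, the ring position proves less decisive than the earlier compounds suggested: there is a 1.9-fold higher number from compound 3 to compound 4 (0.27 log units; within the scatter) and a 1.5-fold lower number from compound 2 to compound 4 (0.19 log units; within the scatter), so hydrogen cannot be told apart from either chloro or methoxy here. The clear step lies elsewhere, with a 4.2-fold lower number from compound 1 to compound 4 (0.63 log units; beyond the scatter), and this puts the gap at the double bond, not at the ring. The high number of compound 1 therefore says nothing about an unsubstituted ring, because both compounds carry that same ring, the decisive point being: the fact that compounds 1 and 4 differ only in the configuration as drawn.

From the compounds shown here alone, only the unsubstituted pair appears in both double-bond forms, so it remains open whether a gap of this size would also appear with chloro or methoxy on the ring. Going by these compounds, what an amine or a carboxylic acid at this ring position would do also remains open.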